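Changing the aryl ether in a thromboxane synthase inhibitor series

A few compounds are considered here, and "the series" means these few. Any claim that something is new, unique, unknown or untested is made for them only; others in the source may bear on it.

Compound 1 `COc1ccc(OC(C)(C)C2OCC(C/C=C\CCC(=O)O)C(c3cccnc3)O2)cc1`: 41 nM
Compound 2 `CC(C)(Oc1ccccc1O)C1OCC(C/C=C\CCC(=O)O)C(c2cccnc2)O1`: 32 nM

In an assay for inhibition of Thromboxane-A synthase (Homo sapiens), using microsomes (on this read-out higher numbers stand for weaker inhibition and lower numbers for stronger inhibition), compound 2 gives 32 nM, the lowest of the two numbers, with compound 1 close by at 41 nM. Compound 3 `CC(C)(Oc1ccc(F)cc1[N+](=O)[O-])C1OCC(C/C=C\CCC(=O)O)C(c2cccnc2)O1` differs from compound 2 in one place: 4-fluoro-2-nitrophenyl in place of 2-hydroxyphenyl on an oxygen on a saturated carbon. For the measured compounds named here, the only measured step that touches this part of the molecule, a 1.3-fold lower number from compound 1 to compound 2 (0.11 log units; within the scatter), swapped one aryl group for another with no change beyond the scatter. Going by the values given here, with no closer precedent, the expected step of a 1.3-fold higher number from compound 2 to compound 3 (0.10 log units; within the scatter) in this assay is small, in either direction. Compound 3 is therefore estimated at 40 nM, within 15 nM to 110 nM.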

Compound 3, half-maximal inhibitory concentration: 20 nM
Estimate against measurement, compound 3: 2.0-fold (0.30 log units) above; measured number inside the range.
By their numbers in this assay, from the lowest: compounds 3, 2 and 1 (each within the scatter of the next, the first and the last beyond it).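

The 4-fluoro-2-nitrophenyl group carries no hydrogen-bond donor and more heavy atoms than the 2-hydroxyphenyl group, yet this swap stays small (a 1.6-fold lower number from compound 2 to compound 3 (0.20 log units; within the scatter)). For the compounds shown here, the comparison with the 4-methoxyphenyl compound gives the first step here to pass the usual scatter, though only modestly (a 2.1-fold lower number from compound 1 to compound 3 (0.31 log units; beyond the scatter)). Nothing available explains these numbers. On these data alone, whether the fluoro or the nitro substituent alone would give the same result remains open. So does the outcome with an amine or a carboxylic acid on the aromatic ring.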